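Shortening the ether side chain of compound 1

The compounds below may be only part of what the source reports. "The series", "measured", "known", "first", "only" and "open" are said of these compounds alone.

Compound 1 `COCCOc1cc2oc(=O)n(CCC(=O)O)c2cc1Cl` gives 31.6 nM in an assay for inhibition of kynurenine 3-monooxygenase (Homo sapiens), read by mass spectrometry, with a stated time of 1 h (a lower number here means a stronger inhibitor, a higher number a weaker inhibitor), the highest of the three numbers in hand, though both others lie within the scatter of it. Compound 2 `O=C(O)CCn1c(=O)oc2cc(OCC3CCC3)c(Cl)cc21` gives 25.1 nM and compound 3 `O=C(O)CCn1c(=O)oc2cc(OCc3ccccc3)c(Cl)cc21` gives 25.1 nM; the steps of a 1.3-fold lower number from compound 1 to compound 2 (0.10 log units; within the scatter) and a 1.3-fold lower number from compound 1 to compound 3 (0.10 log units; within the scatter) are both within the scatter, as is no change at the digits printed from compound 2 to compound 3 (within the scatter). The three measured compounds therefore sit together, and the group on the saturated chain carbon bound to the oxygen on the aromatic ring has so far made no difference that can be told from repeat measurements.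

Compound 4 `COc1cc2oc(=O)n(CCC(=O)O)c2cc1Cl` is the next step from compound 1: hydrogen in place of methoxymethyl on a saturated chain carbon bound to an oxygen on an aromatic ring. The three measured steps each swap one group for another at this place; none removes the group altogether, so they speak to tolerance of the position rather than to what its loss costs. On that basis no large shift is expected, though with less of the chain present a somewhat higher number than that of compound 1 is the more likely direction. The estimate for compound 4 is 60 nM, with a range of 20 nM to 200 nM, which corresponds to an expected step of a 1.9-fold higher number from compound 1 to compound 4 (0.28 log units; within the scatter).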

Compound 4, half-maximal inhibitory concentration: 12.6 nM
For compound 4 the middle estimate is 4.8-fold (0.68 log units) above the measured one; measured number below the stated range.
By their numbers in this assay, from the lowest: compounds 4, 2, 3 and 1 (each within the scatter of the next, the first and the last beyond it).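

Cutting 2-methoxyethoxy back to methoxy is the first change at this place that removes the group on the saturated chain carbon bound to the oxygen on the aromatic ring rather than swapping it, and it costs nothing in this assay: the step is a 2.5-fold lower number from compound 1 to compound 4 (0.40 log units; beyond the scatter), so nothing past the methyl is needed to hold the number in this set. The same removal does not separate the methoxy compound from the other two ethers, with a 2.0-fold lower number from compound 2 to compound 4 (0.30 log units; within the scatter) and a 2.0-fold lower number from compound 3 to compound 4 (0.30 log units; within the scatter), so a gain on removal is seen for the 2-methoxyethoxy compound alone, and the cyclobutyl and phenyl compounds go against any general rule that less chain gives a lower number. No measurement on hand bears on why the shorter ether reads as it does.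

Whether the methyl itself can go is open, since a free hydroxyl at this place is not among the compounds shown. Also open, as far as these compounds go, is how an ethoxy group, or a 2-aminoethoxy chain carrying an amine, would read against the methoxy compound on the shared core.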